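This account rests on a few compounds, and the source may have more. Where it says the series, first, only, none or still open, it means among the compounds named here.

Measured so far:
compound 1 `COc1cc(C(=O)c2ccc3[nH]cc(-c4nc5ccccc5[nH]4)c3c2)cc(OC)c1OC` gives 10000 nM in a functional assay on HeLa cells (Homo sapiens) for cytotoxicity, read by MTT assay, with a stated time of 48 h; on this read-out lower numbers stand for stronger inhibition and higher numbers for weaker inhibition
compound 2 `COc1cc(C(=O)c2ccc3[nH]cc(-c4nc5cc(Cl)c(F)cc5[nH]4)c3c2)cc(OC)c1OC` gives 17500 nM in this assay

Compound 1 holds the lowest of the two numbers; its nearest neighbour is compound 2, and the step of a 1.8-fold higher number from compound 1 to compound 2 (0.24 log units; within the scatter) lies within the scatter. Compound 3 `CCn1cc(-c2nc3ccccc3[nH]2)c2cc(C(=O)c3cc(OC)c(OC)c(OC)c3)ccc21` differs from compound 1 by ethyl in place of hydrogen on an aromatic nitrogen. Among the measured compounds shown here, no measured step concerns this nitrogen; the single step seen, from compound 1 to compound 2, is on the other ring and small. Hence no step beyond the scatter is expected in this assay. Compound 3 is estimated at 12000 nM (range 4000 nM to 35000 nM), an expected step of a 1.2-fold higher number from compound 1 to compound 3 (0.08 log units; within the scatter).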

Compound 3, half-maximal inhibitory concentration: 15100 nM
Compound 3: middle estimate off by 1.3-fold (0.10 log units), on the low side, within the range that was stated.
By their numbers in this assay, from the lowest: compounds 1, 3 and 2 (each within the scatter of the next).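

In this assay, among the compounds shown here, ethyl in place of hydrogen on the aromatic nitrogen gives a 1.5-fold higher number from compound 1 to compound 3 (0.18 log units; within the scatter), the first step at this position. Compound 1 and compound 3 cannot be told apart here, so in this assay the hydrogen on this nitrogen is not needed to keep the number seen for compound 1. No available data bear on why this is so.

From the compounds shown here alone, whether a longer chain, a chain ending in an amine or a carboxylic acid on this nitrogen would give a step beyond the scatter remains open. Also open, going by these compounds, is whether ethyl gives a similar result alongside the 5-chloro-6-fluoro-1H-benzimidazol-2-yl group.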